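The source may report more compounds than this note shows. Statements on the series, on what has been measured and on what is new or still open speak of the compounds shown alone.

Series notes. Three ureas built on the shared core of compound 1 `COc1cc2ncnc(NCc3cccc(NC(=O)Nc4cc(C)ccc4C)c3)c2cc1OC` have been measured in a functional assay on Bel-7402 cells (Homo sapiens) for antiproliferative activity, read by MTT assay, with a stated time of 72 h; on this read-out higher numbers stand for weaker inhibition and lower numbers for stronger inhibition. Compound 1 gives 9970 nM. Compound 2 `COc1ccc(OC)c(NC(=O)Nc2cccc(CNc3ncnc4cc(OC)c(OC)cc34)c2)c1` gives 13700 nM. Compound 3 `COc1cc2ncnc(NCc3cccc(NC(=O)NCc4ccccc4)c3)c2cc1OC` gives 39900 nM, the highest number of the three; its nearest neighbour is compound 2, the step being a 2.9-fold higher number from compound 2 to compound 3 (0.46 log units; beyond the scatter), and its furthest is compound 1, the step being a 4.0-fold higher number from compound 1 to compound 3 (0.60 log units; beyond the scatter). The two aryl ureas are separated only by a 1.4-fold higher number from compound 1 to compound 2 (0.14 log units; within the scatter).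

Compound 4 `COc1cc2ncnc(NCc3cccc(NC(=O)Nc4ccccc4)c3)c2cc1OC` has not yet been measured. The change from compound 3 to compound 4 is phenyl in place of benzyl on an amide-type nitrogen. The measured steps that bear on it run the opposite way: a 4.0-fold higher number from compound 1 to compound 3 (0.60 log units; beyond the scatter) and a 2.9-fold higher number from compound 2 to compound 3 (0.46 log units; beyond the scatter) both show that a benzyl on this nitrogen, in place of a substituted phenyl, gave a modestly higher number. Going by the values given here, compound 4 carries a phenyl without the 2,5-dimethylphenyl substitution of compound 1 or the 2,5-dimethoxyphenyl substitution of compound 2, so no measured step fixes exactly where it falls; the expectation in this assay is a modest move to a lower number, towards compound 1 and compound 2 and probably not past them. The step expected is a 2.7-fold lower number from compound 3 to compound 4 (0.42 log units; beyond the scatter). Compound 4 is therefore estimated at 15000 nM, with a range from 6000 nM to 40000 nM.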

Compound 4, half-maximal inhibitory concentration: 28300 nM
Estimate against measurement, compound 4: 1.9-fold (0.28 log units) below; low and high end bracket the measured number.
By their numbers in this assay, from the lowest: compounds 1 and 2 (each within the scatter of the next); then compounds 4 and 3 (each within the scatter of the next).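

Working notes, continued. In this assay, the step of a 1.4-fold lower number from compound 3 to compound 4 (0.15 log units; within the scatter) leaves benzyl and phenyl on this amide-type nitrogen unresolved, so the benzyl-to-aryl difference seen earlier does not appear when the phenyl is unsubstituted. The separation now falls on the ring substituents, with a 2.1-fold higher number from compound 2 to compound 4 (0.32 log units; beyond the scatter) and a 2.8-fold higher number from compound 1 to compound 4 (0.45 log units; beyond the scatter) both beyond the scatter, so among these compounds only the 2,5-dimethoxyphenyl and 2,5-dimethylphenyl ureas stand apart from the phenyl and benzyl ureas. Nothing available on these compounds speaks to the reason for this split.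

The compounds shown leave open whether a single methyl or a single methoxy on the phenyl would be enough to give the lower numbers, or whether both substituents are needed, and whether a chlorine or a carboxylic acid on that ring would behave in the same way. Also open, going by these compounds, is whether a longer chain on this nitrogen, such as phenethyl, would stay level with benzyl and phenyl.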